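Replacing an arylsulfonyl with ethylsulfonyl in a prostaglandin D2 receptor 2 series

The source may report more compounds than this note shows. Statements on the series, on what has been measured and on what is new or still open speak of the compounds shown alone.

Measured compounds:
compound 1, `COc1ccc(S(=O)(=O)c2ccccc2)c(Cc2c3c(n(CC(=O)O)c2C)CCNC3=O)c1`, 3.6 nM
compound 2, `Cc1c(Cc2cc(Br)ccc2S(=O)(=O)c2ccccc2)c2c(n1CC(=O)O)CCNC2=O`, 3.9 nM
compound 3, `Cc1c(Cc2ccccc2S(=O)(=O)c2cccc(Cl)c2)c2c(n1CC(=O)O)CCNC2=O`, 4 nM

In a functional assay on CHO.K1 cells for antagonist activity at prostaglandin D2 receptor 2 (Homo sapiens), read by GTPgammaS binding, with a stated time of 1 h (on this read-out higher numbers stand for weaker inhibition and lower numbers for stronger inhibition), compound 1 gives 3.6 nM. The step of a 1.1-fold higher number from compound 1 to compound 2 (0.03 log units; within the scatter) shows that bromo in place of methoxy on the aromatic ring leaves the number essentially where it was. Compound 3, carrying a 3-chlorophenyl on its sulfonyl sulfur, gives 4 nM in this assay, and that number sits within the usual scatter of both compound 1 and compound 2; the three values are indistinguishable on this read-out.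

Compound 4, `CCS(=O)(=O)c1ccccc1Cc1c2c(n(CC(=O)O)c1C)CCNC2=O`, is not yet measured. Its difference from compound 3 is ethyl in place of 3-chlorophenyl on a sulfonyl sulfur. Among the compounds with values here, none of the measured steps touches the group on the sulfonyl sulfur: the only single-point step, from compound 1 to compound 2, concerns a substituent elsewhere on the benzylic ring, and compounds 1 and 3 differ in two places at once, so their values alone say nothing about the sulfonyl substituent. Within the data shown here, every measured compound carries an aromatic ring on that sulfur, and compound 4 is the first to carry a chain there, so the change is untested. The expected step for compound 4 is therefore uncertain, a 3.8-fold higher number from compound 3 to compound 4 (0.57 log units; beyond the scatter), with a wide range. Compound 4 is estimated to give 15 nM in this assay, expected between 4 nM and 60 nM.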

Compound 4, half-maximal inhibitory concentration: 550 nM
The estimate for compound 4 lay 37-fold (1.56 log units) below the measured number; the whole stated range lies below it.
By their numbers in this assay, from the lowest: compounds 1, 2 and 3 (each within the scatter of the next); then compound 4.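

The group on the sulfonyl sulfur matters far more in this assay than the one other single change among these compounds: ethyl in place of 3-chlorophenyl gives a 140-fold higher number from compound 3 to compound 4 (2.14 log units; beyond the scatter), whereas bromo in place of methoxy on an aromatic carbon gives only a 1.1-fold higher number from compound 1 to compound 2 (0.03 log units; within the scatter). This position, on a sulfonyl sulfur whose other neighbour is an aromatic carbon, therefore does not accept every group, and the low numbers shared by compounds 1, 2 and 3 all come with an aromatic ring on that sulfur, while compound 4, the only one here with a chain there, gives 550 nM and stands well apart. Nothing available here explains this loss of inhibition.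

The exchange from 3-chlorophenyl to ethyl removes the ring, the chlorine and several heavy atoms at once, so this single pair cannot show which of these differences accounts for the step. A cyclohexyl, a benzyl or a longer chain such as butyl on the same sulfur would begin to separate the need for an aromatic ring from the need for a larger group.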